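Adding a sulfonyl group to the ring nitrogen of compound 3

The source may report more compounds than this note shows. Statements on the series, on what has been measured and on what is new or still open speak of the compounds shown alone.

compound 1 (`CN1C/C(=C\c2ccncc2)C(=O)/C(=C/c2ccc(C#N)cc2)C1`) gives 18500 nM
compound 2 (`O=C1/C(=C/c2cccnc2)CNC/C1=C\c1ccccc1F`) gives > 20000 nM as a limit
compound 3 (`O=C1/C(=C/c2cccnc2)CNC/C1=C\c1ccccc1C(F)(F)F`) gives 5100 nM

Going by the values given here, all three results come from a functional assay on SMMC-7721 cells (Homo sapiens) for cytotoxicity, read by MTT assay, with a stated time of 24 h (a lower number here means a stronger inhibitor, a higher number a weaker inhibitor), and only two of them are numbers. Compound 3 has the lower of these two numbers, at 5100 nM against the higher number of compound 1 at 18500 nM in this assay, a gap beyond the scatter. Compound 2 gives > 20000 nM as a limit of the assay and not a number.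

The next compound is compound 4 (`O=C1/C(=C/c2cccnc2)CN(S(=O)(=O)c2ccc(F)cc2)C/C1=C\c1ccccc1C(F)(F)F`), which carries (4-fluorophenyl)sulfonyl in place of hydrogen on an amine nitrogen in a ring.

Among the compounds with values here, the only measured step, an at least 3.9-fold lower number from compound 2 to compound 3 (0.59 log units; beyond the scatter) in size, is trifluoromethyl in place of fluoro on an aromatic carbon. Within the data shown here, it bears only indirectly on a change at the amine nitrogen, where no step has been measured. Compound 1 differs from compound 3 in more than one place, so its value does not isolate that nitrogen either.

No step beyond the scatter is therefore expected in this assay, with a slight lean towards a lower number and a wide range kept open. The expected step is a 1.5-fold lower number from compound 3 to compound 4 (0.16 log units; within the scatter) as an estimate. For compound 4 the estimated value is 3500 nM (expected range 800 nM to 15000 nM).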

Compound 4, half-maximal inhibitory concentration: 6390 nM
Beside the measured number, compound 4's estimate is 1.8-fold (0.26 log units) below it; low and high end bracket the measured number.
By their numbers in this assay, from the lowest: compounds 3 and 4 (each within the scatter of the next); then compound 1. At a limit, above all of these: compound 2.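

In this assay, going by these compounds alone, (4-fluorophenyl)sulfonyl in place of hydrogen on the ring amine nitrogen gives a 1.3-fold higher number from compound 3 to compound 4 (0.10 log units; within the scatter), which is the only measured step at this nitrogen. This position therefore carries a substituent of 10 heavy atoms, with one six-membered aromatic ring, and the value stays within the scatter of the hydrogen-bearing parent, so on this pair the hydrogen on that nitrogen is not needed to hold the level of compound 3 in this assay. No measurement shown gives a reason for the size of this step.

Within the data shown here, only one sulfonyl group stands on this nitrogen with this pair of aromatic groups, and compound 1, which carries methyl there, differs in other places too, so the step says nothing on how far the outcome depends on the 4-fluorophenyl part. From the compounds shown here alone, whether methanesulfonyl, an acetyl group, a longer alkyl chain or an aminoalkyl chain on this nitrogen would stay within the scatter of compound 3, or move beyond it, remains open.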